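The source may report more compounds than this note shows. Statements on the series, on what has been measured and on what is new or still open speak of the compounds shown alone.

Compound 1, with the structure `Cn1c(=O)c(C(=O)Nc2ccccc2N)c(O)c2ccccc21`, and compound 2, with the structure `Nc1ccccc1NC(=O)c1c(O)c2ccccc2n(-c2ccccc2)c1=O`, share one core and differ in a single place: phenyl in place of methyl on an aromatic nitrogen. In a functional assay, with a stated time of 60 min, tested at 0.1 mM (on this read-out lower numbers stand for a weaker effect and higher numbers for a stronger effect at the one concentration tested), compound 1 gives 13.5%, while compound 2 gives 16.3%; the step is a number 2.8 percentage points higher from compound 1 to compound 2 (within the scatter). Compound 3, with the structure `Cn1c(=O)c(C(=O)NCCCCCCNC(=O)CCCCC2CCSS2)c(O)c2ccccc21`, carries the same core as compound 1 but a different amide side chain; the difference between the two cores is not broken down here. In this assay compound 3 gives 13%, which sits within the scatter of the numbers for compound 1 and compound 2. Compound 4, with the structure `O=C(CCCCC1CCSS1)NCCCCCCNC(=O)c1c(O)c2ccccc2n(-c2ccccc2)c1=O`, has not yet been measured. It differs from compound 3 by phenyl in place of methyl on an aromatic nitrogen, the same change as that from compound 1 to compound 2, at a place described in identical words. For compound 4 the expected step is a number 2 percentage points higher from compound 3 to compound 4 (within the scatter). That expectation rests on the small step of a number 2.8 percentage points higher from compound 1 to compound 2 (within the scatter) seen with the same change. Compound 4 is therefore estimated at 15%, with a range from 5% to 26%.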

Compound 4, a percentage reported as activity, at one concentration (the size of the read-out at that concentration, not a potency): 10.2%
The estimate for compound 4 lay 4.8 percentage points above the measured number, and the stated range covers the measured number.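

In this assay, phenyl in place of methyl on an aromatic nitrogen gives a second step on the core with the longer amide side chain, a number 2.8 percentage points lower from compound 3 to compound 4 (within the scatter). Set beside the earlier step, the two readings do not separate: the same change on two cores in this assay, a number 2.8 percentage points higher (within the scatter) from compound 1 to compound 2 and a number 2.8 percentage points lower (within the scatter) from compound 3 to compound 4, 5.6 percentage points apart, within the scatter of two such steps. In these two pairs the change stays within the scatter on both cores, which fits with it carrying over as a small step, but it does not show that the change has no effect, nor does it fix a direction or a size for the step on any other core.

The compounds shown leave open how other groups on that aromatic nitrogen, such as ethyl or benzyl, would read in this assay, and whether a longer chain or an amine or a carboxylic acid in the amide side chain would alter the picture. They also leave open how the four compounds would compare at concentrations other than the single one tested.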